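Swapping the side chain on compound 2's amine nitrogen

The source may hold more compounds than are shown below. What is called first, only, known or untested is meant among the compounds shown, and "the series" means these compounds.

- compound 1 `CC(C)(C)C1=CC(=O)C=C(NCCC(=O)O)C1=O` with 67000 nM as its value
- compound 2 `CSCC[C@H](NC1=CC(=O)C=C(C[C@]2(C)[C@@H](C)CC[C@]3(C)C(C)=CCC[C@@H]23)C1=O)C(=O)O` with 13600 nM as its value
- compound 3 `CC(C)C[C@H](NC1=CC(=O)C=C(C(C)(C)C)C1=O)C(=O)O` with 76500 nM as its value

All three values come from a functional assay on K562 cells (Homo sapiens) for cytotoxicity, read by MTT assay, with a stated time of 72 h (a higher number here means a weaker inhibitor, a lower number a stronger inhibitor), and compound 2 has the lowest number of the set. Compound 1 and compound 3 both lie above it by more than the usual scatter, while their two values lie within the scatter of each other.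

The next compound to be measured is compound 4 `CC1=CCC[C@H]2[C@](C)(CC3=CC(=O)C=C(N[C@@H](C(=O)O)C(C)C)C3=O)[C@@H](C)CC[C@]12C` which keeps the core of compound 2 and alters one group: 1-carboxy-2-methylpropyl in place of 1-carboxy-3-(methylsulfanyl)propyl on an amine nitrogen. Among the measured compounds shown here, no measured pair shows a step of this kind, so the expectation rests on indirect evidence. The nearness of compound 1 (67000 nM) and compound 3 (76500 nM) suggests that the group on the nitrogen need not move the number much, although those two compounds have a different core from compound 2. The expected step of a 1.2-fold higher number from compound 2 to compound 4 (0.07 log units; within the scatter) therefore stays within the scatter, with no firm direction. For compound 4 the estimated value is 16000 nM in this assay and the expected range runs from 7000 nM to 36000 nM overall.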

Compound 4, half-maximal inhibitory concentration: 7780 nM
Beside the measured number, compound 4's estimate is 2.1-fold (0.31 log units) above it; low and high end bracket the measured number.
By their numbers in this assay, from the lowest: compounds 4 and 2 (each within the scatter of the next); then compounds 1 and 3 (each within the scatter of the next).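

Among the compounds shown here, the pair of compound 2 and compound 4 is the first in the set to isolate the side chain on the amine nitrogen while the rest of the structure stays the same. In this assay, placing 1-carboxy-2-methylpropyl where 1-carboxy-3-(methylsulfanyl)propyl stood gives a 1.7-fold lower number from compound 2 to compound 4 (0.24 log units; within the scatter) and so shows that, on this core, the sulfur-bearing chain can be exchanged for this branched one with no difference that stands clear of the scatter. No independent measurement is available to explain this result.

The compounds shown leave open whether this tolerance extends to side chains of a different kind on the same nitrogen, such as one carrying a phenyl ring, a basic amine or a second carboxylic acid. They also leave open whether the carboxylic acid of the side chain matters at all, a question that a methyl ester or a primary amide in its place on the core of compound 2 could address.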